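A few compounds are considered here, and "the series" means these few. Any claim that something is new, unique, unknown or untested is made for them only; others in the source may bear on it.

Of the compounds shown here, two sharing one core have been tested in an ADME assay on Vero cells (Chlorocebus sabaeus) for cytotoxicity, with a stated time of 72 h; on this read-out higher numbers stand for weaker inhibition and lower numbers for stronger inhibition. In this assay compound 1 `CCOC(=O)c1cc(-c2cccc(OCc3cccc(Cl)c3)c2)on1` gives > 128000 nM, which is a limit of the assay rather than a number. Compound 2 `CCOC(=O)c1cc(-c2cccc(OCc3ccccc3C(F)(F)F)c2)on1` likewise reaches only a limit, > 128000 nM, in this assay. Where compound 2 stands is thus known only as this limit, the same one at which every value shown sits (the limit of > 128000 nM in this assay, at which 2 of the 2 values shown sit). Compound 3 `CCOC(=O)c1cc(-c2cccc(OCc3ccccc3Cl)c2)on1` differs from compound 2 by a single change, (chloro in place of trifluoromethyl on an aromatic carbon), chloro in place of trifluoromethyl on an aromatic carbon. Within the data shown here, no measured step between two compounds differing in one place exists here, so the size of this change cannot be read from the numbers; with both values resting at the limit, no shift beyond the scatter is expected in this assay. Compound 3 is therefore expected to give 200000 nM, within 100000 nM and 500000 nM, most likely reported again only as a limit. The expected step from compound 2 to compound 3 is a step that the limit leaves unreadable from compound 2 to compound 3.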

Compound 3, half-maximal inhibitory concentration: > 128000 nM
Compound 3: a limit, no number; the forecaster's own chance of this, stated with the estimate: 85%; the middle value does not contradict the limit.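

Among these compounds, compound 1, compound 2 and compound 3 all rest at a limit rather than a number in this assay, so no step among them can be read: the limit of > 128000 nM in this assay, at which 3 of the 3 values shown sit. Left open is whether chloro in place of trifluoromethyl, or 2-chlorophenyl in place of 3-chlorophenyl, changes this read-out at all.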